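Furan-bearing core: from thioester to sec-butyl ester

The source may report more compounds than this note shows. Statements on the series, on what has been measured and on what is new or still open speak of the compounds shown alone.

Compound 1 `CC1=C(C(=O)CC(C)C)C(c2ccco2)NC(=O)N1`: 31%
Compound 2 `CCNC(=O)C1=C(C)NC(=O)NC1c1ccco1`: 3%
Compound 3 `CC1=C(C(=O)SC(C)C)C(c2ccco2)NC(=O)N1`: 1%

In an assay on membranes from HeLa cells for displacement of a labelled ligand from adenosine receptor A3 (Homo sapiens), read by scintillation counting, with a stated time of 180 min, tested at 1 uM (a higher number here means more inhibition at the concentration tested (going by the name of the read-out), a lower number less inhibition), compound 3 gives the lowest of the three numbers; compound 2 sits within the scatter of it, while compound 1 stands well above it. Compound 4 `CCC(C)OC(=O)C1=C(C)NC(=O)NC1c1ccco1` differs from compound 3 by sec-butoxy in place of isopropylsulfanyl on a carbonyl carbon. Two measured steps end at the same isopropylsulfanyl group: a number 30 percentage points lower from compound 1 to compound 3 (beyond the scatter) and a number 2 percentage points lower from compound 2 to compound 3 (within the scatter). Within the data shown here, no ester has been measured, so the new group has no direct precedent. The two groups that differ from isobutyl gave low numbers, and the estimate therefore leans low: compound 4 is expected at 8%, between 0% and 25%, a step of a number 7 percentage points higher from compound 3 to compound 4 (within the scatter) that is expected to stay within the scatter.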

Compound 4, a percentage reported as inhibition, at one concentration (the size of the read-out at that concentration, not a potency): 3%
Compound 4: the middle estimate sits 5 percentage points above what was measured; measured number inside the range.
By their numbers in this assay, from the lowest: compounds 3, 2 and 4 (each within the scatter of the next); then compound 1.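

Sec-butoxy on this carbonyl carbon reads like isopropylsulfanyl and ethylamino in this assay: a number 2 percentage points higher from compound 3 to compound 4 (within the scatter) and no change at the digits printed from compound 2 to compound 4 (within the scatter). Only isobutyl stands apart so far, with a number 28 percentage points lower from compound 1 to compound 4 (beyond the scatter), so among these four compounds the oxygen-linked, sulfur-linked and nitrogen-linked groups all sit low and compound 1 is the exception. Nothing available explains this difference. As far as these compounds go, whether a longer carbon chain or a phenyl group on the carbonyl carbon would hold or raise the number of compound 1 stays open. So does whether a small methoxy group would read like sec-butoxy.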